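The source may hold more compounds than are shown below. What is called first, only, known or untested is meant among the compounds shown, and "the series" means these compounds.

Compound 1, `N#Cc1nc2c(-c3nc4ccccc4[nH]3)c(N)n(CCN3CCCC3)c2nc1C#N`: in a functional assay on HL-60 cells (Homo sapiens) for antiproliferative activity, read by MTT assay, with a stated time of 48 h (a higher number here means a weaker inhibitor, a lower number a stronger inhibitor), compound 1 gives 4760 nM.
Compound 2, `N#Cc1nc2c(-c3nc4ccccc4[nH]3)c(N)n(CCO)c2nc1C#N`: in this assay compound 2 gives only a limit, > 50000 nM.
Compound 3, `N#Cc1nc2c(-c3nc4ccccc4[nH]3)c(N)n(CCCN3CCCCC3)c2nc1C#N`: in this assay compound 3 gives 1680 nM.

Of the two numbers that are not limits, compound 1 stands highest; compound 3 sits below it by a 2.8-fold lower number from compound 1 to compound 3 (0.45 log units; beyond the scatter). Compound 4, `CCN(CC)CCCCn1c(N)c(-c2nc3ccccc3[nH]2)c2nc(C#N)c(C#N)nc21`, has not yet been measured. It differs from compound 1 in one place: 2-(diethylamino)ethyl in place of pyrrolidin-1-yl on a saturated chain carbon, two bonds along the chain from an aromatic nitrogen. Two measured steps at this position bear on it. Putting hydroxy in place of pyrrolidin-1-yl gave an at least 10-fold higher number from compound 1 to compound 2 (1.02 log units; beyond the scatter), a large loss that ran into the limit described by the limit of > 50000 nM in this assay, at which 1 of the 3 values shown sits. Putting (piperidin-1-yl)methyl in place of pyrrolidin-1-yl gave a 2.8-fold lower number from compound 1 to compound 3 (0.45 log units; beyond the scatter), a modest gain. Compound 4 keeps an amine nitrogen on the chain and lengthens the chain, as compound 3 does, so the step expected is a modest fall in the number, a 1.9-fold lower number from compound 1 to compound 4 (0.28 log units; within the scatter). The estimate for compound 4 is 2500 nM, with a range from 1000 nM to 6500 nM.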

Compound 4, half-maximal inhibitory concentration: 460 nM
Beside the measured number, compound 4's estimate is 5.4-fold (0.74 log units) above it, and the stated range ends above it.
By their numbers in this assay, from the lowest: compound 4; then compound 3; then compound 1. At a limit, above all of these: compound 2.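

In this assay, 4-(diethylamino)butyl in place of 2-(pyrrolidin-1-yl)ethyl gives a 10-fold lower number from compound 1 to compound 4 (1.01 log units; beyond the scatter), a large step where the earlier change between amine side chains was only modest. The open-chain amine also goes past the piperidine compound, with a 3.7-fold lower number from compound 3 to compound 4 (0.56 log units; beyond the scatter), so the three amine-bearing compounds are separated from one another by steps beyond the scatter, and carrying an amine on the chain does not alone set the number. The step from the hydroxy compound, an at least 100-fold lower number from compound 2 to compound 4 (2.03 log units; beyond the scatter), starts from a limit, so its size is only a bound: the limit of > 50000 nM in this assay, at which 1 of the 4 values shown sits.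

As far as these compounds go, whether the gain belongs to the longer chain or to the diethylamino group stays open, as the two change together from compound 1 to compound 4. A 4-(pyrrolidin-1-yl)butyl chain would bear on that, and a 5-(diethylamino)pentyl chain would show whether lengthening goes further.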